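Changing the Carboxy-Bearing Amino Group on a Shared Core

The source may hold more compounds than are shown below. What is called first, only, known or untested is meant among the compounds shown, and "the series" means these compounds.

Within the data shown here, in a functional assay on MCF7 cells (Homo sapiens) for inhibition, read by MTT assay, with a stated time of 3 days (a higher number here means a weaker inhibitor, a lower number a stronger inhibitor), compound 1 (`CC[C@H](C)[C@H](NCC(=O)NNC(=O)COc1ccc(-c2nc3ccccc3s2)cc1OC)C(=O)O`) gives 1710 nM and compound 2 (`COc1cc(-c2nc3ccccc3s2)ccc1OCC(=O)NNC(=O)CN(C(C)=O)[C@@H](CS)C(=O)O`) gives 1750 nM, so compound 2 stands level with compound 1 within the scatter, and these are the only two numbers available. Compound 3 (`COc1cc(-c2nc3ccccc3s2)ccc1OCC(=O)NNC(=O)CN[C@@H](CCSC)C(=O)O`) keeps the core of compound 2 and differs in one group ((1-carboxy-3-(methylsulfanyl)propyl)amino in place of acetyl(1-carboxy-2-sulfanylethyl)amino on a saturated chain carbon bound to a carbonyl carbon): (1-carboxy-3-(methylsulfanyl)propyl)amino in place of acetyl(1-carboxy-2-sulfanylethyl)amino on a saturated chain carbon bound to a carbonyl carbon. Among the measured compounds shown here, one measured step bears on this place: putting acetyl(1-carboxy-2-sulfanylethyl)amino in place of (1-carboxy-2-methylbutyl)amino gave a 1.0-fold higher number from compound 1 to compound 2 (0.01 log units; within the scatter) and so left the number within the scatter. From the compounds shown here alone, compound 3 carries no acetyl, as compound 1 does not, but its group itself is untested, and a single step is thin evidence. In this assay no step beyond the scatter is therefore expected, and the estimated change is a 1.0-fold lower number from compound 2 to compound 3 (0.01 log units; within the scatter) for this pair. For compound 3 the estimate is 1700 nM with an expected range from 650 nM to 4500 nM in this measurement.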

Compound 3, half-maximal inhibitory concentration: 1950 nM
The estimate for compound 3 lay 1.1-fold (0.06 log units) below the measured number, and the stated range covers the measured number.
By their numbers in this assay, from the lowest: compounds 1, 2 and 3 (each within the scatter of the next).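

The exchange of acetyl(1-carboxy-2-sulfanylethyl)amino for (1-carboxy-3-(methylsulfanyl)propyl)amino on a saturated chain carbon bound to a carbonyl carbon gave a 1.1-fold higher number from compound 2 to compound 3 (0.05 log units; within the scatter) in this assay and so stayed within the scatter, as the earlier step at this place had done. The comparison of the two compounds without an acetyl adds a cleaner change, 2-(methylsulfanyl)ethyl in place of sec-butyl on a saturated chain carbon bound to an amine nitrogen and a carbonyl carbon, which gave a 1.1-fold higher number from compound 1 to compound 3 (0.06 log units; within the scatter) and also stayed within the scatter. All three carboxy-bearing amino groups therefore stand level on the shared core in this measurement, and no supporting evidence is available to account for that.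

All three groups carry a carboxylic acid, so the compounds shown leave open whether the number would hold with a methyl ester or an amide in its place. They also leave open whether a group of another kind on the chain, such as a primary amine, a phenyl ring or a much longer alkyl chain, would move the number beyond the scatter.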